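The source may hold more compounds than are shown below. What is called first, only, known or untested is meant among the compounds shown, and "the series" means these compounds.

Measured compounds in a functional assay on MCF7 cells (Homo sapiens) for cytotoxicity, with a stated time of 72 h; on this read-out higher numbers stand for weaker inhibition and lower numbers for stronger inhibition:

Compound 1, `CC(C)[C@H](NC(=O)c1cc(Cl)ccc1O)C(=O)Nc1ccc(Cl)cc1`: compound 1 gives > 10000 nM, a limit of the assay rather than a number.
Compound 2, `O=C(CNC(=O)c1cc(Cl)ccc1O)Nc1cccc(Cl)c1`: compound 2 gives > 10000 nM, again a limit and not a number.
Compound 3, `CC(C)(C)[C@H](NC(=O)c1cc(Cl)ccc1O)C(=O)Nc1cccc(C(F)(F)F)c1`: compound 3 gives 8800 nM.

Compound 1 stands at the limit of this assay, as does compound 2; only compound 3 yields a number, and that number sits close to the same limit (the limit of > 10000 nM in this assay, at which 2 of the 3 values shown sit). Among the measured compounds shown here, no two measured compounds differ in a single place, so no measured step can be read off.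

Compound 4, `CC(C)[C@H](NC(=O)c1cc(Cl)ccc1O)C(=O)Nc1ccccc1`, is the next compound to be measured in this assay. It differs from compound 1 by hydrogen in place of chloro on an aromatic carbon, para to a large group; read one bond further out, a 4-chlorophenyl becomes a phenyl.

With compound 1 at the limit, an expected step can only be a guess: the estimate for compound 4 is 15000 nM, with a range from 5000 nM to 50000 nM, and the expected step that the limit leaves unreadable from compound 1 to compound 4 is taken as none beyond the scatter, with the value most likely again reported only as a limit.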

Compound 4, half-maximal inhibitory concentration: > 10000 nM
Compound 4: no number, only a limit; the forecaster's own chance of this, stated with the estimate: 70%; the middle value does not contradict the limit.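

In this assay, among the compounds shown here, compound 4 gives only a limit, as does compound 1, so no step between them can be read: the limit of > 10000 nM in this assay, at which 3 of the 4 values shown sit. The compounds shown leave open whether hydrogen in place of chloro on an aromatic carbon changes cytotoxicity at all.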